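The source may hold more compounds than are shown below. What is called first, only, known or untested is meant among the compounds shown, and "the series" means these compounds.

Series notes, kinetic solubility.

Compound 1 `Cn1ccc2ccc(-c3cc(Nc4ccccc4S(N)(=O)=O)cc4nccnc34)cc21` carries a primary sulfonamide and in a physicochemical assay for solubility, read by spectrophotometry, measured as kinetic solubility, at pH 8, tested at 500 uM (on this read-out higher numbers stand for higher solubility and lower numbers for lower solubility), compound 1 gives 6 ug/mL. Among the compounds with values here, compound 2 `Cn1cc(CNS(=O)(=O)c2ccccc2Nc2cc(-c3ccc4ccn(C)c4c3)c3nccnc3c2)cn1` adds a (1-methyl-1H-pyrazol-4-yl)methyl group on the sulfonamide nitrogen, and in this assay compound 2 gives 2 ug/mL; the one measured step is a 3.0-fold lower number from compound 1 to compound 2 (0.48 log units; beyond the scatter). Compound 3 `Cn1cc(NC(=O)c2ccncc2Nc2cc(-c3ccc4ccn(C)c4c3)c3nccnc3c2)cn1` replaces the sulfonamide with a carboxamide bearing a 1-methyl-1H-pyrazol-4-yl group on the amide-type nitrogen, and in this assay compound 3 gives 2 ug/mL. Compound 3 therefore stands level with compound 2 at the digits shown, the two together at the low end of the three numbers, and sits clearly under compound 1.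

Compound 4 `CC(=O)N1CCOC(CNC(=O)c2ccncc2Nc2cc(-c3ccc4ccn(C)c4c3)c3nccnc3c2)C1` is the next member. Relative to compound 3 the difference is (4-acetylmorpholin-2-yl)methyl in place of 1-methyl-1H-pyrazol-4-yl on an amide-type nitrogen. Within the data shown here, no measured step exchanges one substituent for another on this amide-type nitrogen; the only step available, from compound 1 to compound 2, concerns adding a group to a sulfonamide nitrogen and is of modest size, so it gives only a loose guide. Starting from the value of compound 3, the expected step is a 1.5-fold higher number from compound 3 to compound 4 (0.18 log units; within the scatter), with no confident direction beyond the scatter. For compound 4 in this assay the estimate is 3 ug/mL, expected to fall between 1 ug/mL and 9 ug/mL.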

Compound 4, solubility: 268 ug/mL
The estimate for compound 4 lay 89-fold (1.95 log units) below the measured number; measured number outside the range, above it.
By their numbers in this assay, from the lowest: compounds 2 and 3 (each within the scatter of the next); then compound 1; then compound 4.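

Within the data shown here, on the amide-type nitrogen whose other neighbour is the carbonyl carbon, the substituent alone can move the read-out in this assay much further than the earlier compounds showed: (4-acetylmorpholin-2-yl)methyl in place of 1-methyl-1H-pyrazol-4-yl gives a 130-fold higher number from compound 3 to compound 4 (2.13 log units; beyond the scatter), whereas the only earlier step, on a sulfonamide nitrogen, was a 3.0-fold lower number from compound 1 to compound 2 (0.48 log units; beyond the scatter). The exchange replaces a five-membered aromatic ring with a six-membered non-aromatic ring and adds a double bond outside aromatic rings, while the counts of hydrogen-bond donors and acceptors stay the same, so those two counts do not separate compound 3 from compound 4. No measurement at hand bears on why the number moved so far.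

The compounds shown leave open whether the step belongs to the acetyl group, the morpholine ring or the loss of the aromatic ring, since all of these change together; a free morpholine amine or a plain hydroxyethyl chain on the same nitrogen would help to separate them. Also open, from the compounds shown here alone, is whether (4-acetylmorpholin-2-yl)methyl would have a similar effect on the sulfonamide nitrogen of compound 2.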